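Swapping the Aryl Urea Cap on a Quinazoline-Type Scaffold

The source may hold more compounds than are shown below. What is called first, only, known or untested is meant among the compounds shown, and "the series" means these compounds.

Measured so far, in a functional assay on A549 cells (Homo sapiens) for antiproliferative activity, read by MTT assay; a lower number here means a stronger inhibitor, a higher number a weaker inhibitor:
Compound 1, `Cc1ccccc1NC(=O)Nc1cccc(CNc2ncnc3ccccc23)c1`, gives 40200 nM.
Compound 2, `Cc1cccc(NC(=O)Nc2cccc(CNc3ncnc4ccccc34)c2)c1`, gives 30200 nM.
Compound 3, `O=C(Nc1cccc(CNc2ncnc3ccccc23)c1)Nc1ccccc1F`, gives 26100 nM.

Compound 3 carries the lowest of these three numbers, yet its separation from the others is small: a 1.5-fold lower number from compound 1 to compound 3 (0.19 log units; within the scatter) and a 1.2-fold lower number from compound 2 to compound 3 (0.06 log units; within the scatter), both within the scatter, as is a 1.3-fold lower number from compound 1 to compound 2 (0.12 log units; within the scatter). Compound 4, `O=C(Nc1cccc(CNc2ncnc3ccccc23)c1)Nc1cccc(C(F)(F)F)c1`, alters the same aryl cap: 3-(trifluoromethyl)phenyl in place of 2-fluorophenyl on an amide-type nitrogen. Every measured change at this position has left this assay essentially unmoved, so a similarly flat outcome is expected, a 1.0-fold higher number from compound 3 to compound 4 (0.01 log units; within the scatter), with no direction beyond the scatter. Compound 4 is therefore estimated at 27000 nM, plausibly between 9000 nM and 80000 nM.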

Compound 4, half-maximal inhibitory concentration: 44200 nM
For compound 4 the middle estimate is 1.6-fold (0.21 log units) below the measured one; measured number inside the range.
By their numbers in this assay, from the lowest: compounds 3, 2, 1 and 4 (each within the scatter of the next).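

Even at 10 heavy atoms against 7, 3-(trifluoromethyl)phenyl in place of 2-fluorophenyl stays within the scatter in this assay (a 1.7-fold higher number from compound 3 to compound 4 (0.23 log units; within the scatter)). The same holds when compound 4 is set against the two methyl-bearing caps (a 1.5-fold higher number from compound 2 to compound 4 (0.17 log units; within the scatter); a 1.1-fold higher number from compound 1 to compound 4 (0.04 log units; within the scatter)), so trifluoromethyl joins fluoro and methyl in leaving this position flat. No supporting measurement bears on why this is so.

As far as these compounds go, whether a cap carrying an amine or a carboxylic acid would move the number beyond the scatter remains open. So does whether changes to the shared core would matter more than changes to the cap.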